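Quinoxaline dioxide amides: methoxy to fluoro, cytotoxicity outlook

A few compounds are considered here, and "the series" means these few. Any claim that something is new, unique, unknown or untested is made for them only; others in the source may bear on it.

The series shares one core, varied only at a single aromatic carbon of the fused system. Compound 1 `CC(=O)Oc1ccccc1C(=O)Nc1c(C#N)[n+]([O-])c2cc(Cl)ccc2[n+]1[O-]` carries chloro there, and in an ADME assay on cells (Peritoneal macrophage cell, Mus musculus) for cytotoxicity, read by trypan blue exclusion, with a stated time of 48 h (on this read-out lower numbers stand for higher toxicity in this test and higher numbers for lower toxicity in this test), compound 1 is recorded as "not determined" (no result reported). Compound 2 `CC(=O)Oc1ccccc1C(=O)Nc1c(C#N)[n+]([O-])c2cc(C)ccc2[n+]1[O-]` carries methyl, and in this assay compound 2 gives 21700 nM. Compound 3 `COc1ccc2c(c1)[n+]([O-])c(C#N)c(NC(=O)c1ccccc1OC(C)=O)[n+]2[O-]` carries methoxy; in this assay compound 3 is recorded as "not determined" (no result reported), so the only measured point in the set remains compound 2. Where compound 3 stands on the numbers therefore cannot be said; it stands alongside compound 1 as a second entry without a result.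

Compound 4 `CC(=O)Oc1ccccc1C(=O)Nc1c(C#N)[n+]([O-])c2cc(F)ccc2[n+]1[O-]` differs from compound 3 by fluoro in place of methoxy on an aromatic carbon, meta to a fused ring and para to a fused ring. Within the data shown here, no measured step between two compounds of this kind exists, so the direction of the change in this assay cannot be read from the data. The expectation rests on compound 2 and its value of 21700 nM as the sole anchor. Compound 4 is expected to give 20000 nM in this assay, with a range from 5000 nM to 80000 nM. Given that two of three analogues returned no number, a result as a limit rather than a value is a real possibility.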

Compound 4, half-maximal cytotoxic concentration: 13600 nM
The estimate for compound 4 lay 1.5-fold (0.17 log units) above the measured number; low and high end bracket the measured number.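

In this assay, fluoro in place of methyl on the aromatic carbon meta to a fused ring and para to a fused ring gives a 1.6-fold lower number from compound 2 to compound 4 (0.20 log units; within the scatter), so these two groups cannot be told apart on this read-out. Steps involving compound 1 or compound 3 cannot be read, since neither compound carries a single number, and the methoxy-to-fluoro change therefore has no measured size. No supporting data bear on why fluoro and methyl give such similar results.

On these data alone, it remains open whether an amine, a carboxylic acid or a longer chain such as ethoxy on this aromatic carbon would shift the number beyond the usual scatter. Two compounds also cannot show whether this carbon matters to the read-out at all, or how much of it is set by the shared core.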